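Swapping Methyl for Trifluoromethyl: Expected Liver Stability

The source may report more compounds than this note shows. Statements on the series, on what has been measured and on what is new or still open speak of the compounds shown alone.

Compound 3 `COc1ccn2c(-c3ccc(NC(=O)c4ccc([N+](=O)[O-])o4)c(C)c3)cnc2c1` gives 0.665 h in an ADME assay on microsomes from liver (Homo sapiens) for metabolic stability; on this read-out lower numbers stand for a shorter-lived compound and higher numbers for a longer-lived compound. Its number sits within the scatter of compound 2 `COc1ccn2c(-c3ccc(NC(=O)c4ccc([N+](=O)[O-])o4)c(C)c3C(F)(F)F)cnc2c1`, which gives 0.835 h, and of compound 1 `COc1ccn2c(-c3ccc(NC(=O)c4ccc([N+](=O)[O-])o4)cc3)cnc2c1`, which gives 0.472 h, so no ordering among the three can be claimed. Compound 4 `COc1ccn2c(-c3ccc(NC(=O)c4ccc([N+](=O)[O-])o4)c(C(F)(F)F)c3)cnc2c1` has not yet been measured; it differs from compound 3 by trifluoromethyl in place of methyl on an aromatic carbon. For the measured compounds named here, two measured steps bear on this: a 1.4-fold higher number from compound 1 to compound 3 (0.15 log units; within the scatter) and a 1.3-fold lower number from compound 2 to compound 3 (0.10 log units; within the scatter). Both are small, and the trifluoromethyl entering here is the same group that left in the second step. The step expected in this assay is therefore modest, a 1.2-fold higher number from compound 3 to compound 4 (0.07 log units; within the scatter), not beyond the scatter. Compound 4 is accordingly estimated at 0.78 h, with a range from 0.4 h to 1.5 h.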

Compound 4, half-life: 0.403 h
For compound 4 the middle estimate is 1.9-fold (0.29 log units) above the measured one, and the stated range covers the measured number.
By their numbers in this assay, from the lowest: compounds 4, 1, 3 and 2 (each within the scatter of the next, the first and the last beyond it).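

In this assay, this position, ortho to a large group and meta to a large group, now has three groups compared: trifluoromethyl gives a 1.7-fold lower number from compound 3 to compound 4 (0.22 log units; within the scatter) against methyl and a 1.2-fold lower number from compound 1 to compound 4 (0.07 log units; within the scatter) against hydrogen. Neither step lies beyond the scatter, so swapping among these three groups here has no clear effect on half-life. Losing trifluoromethyl also reads alike on two different compound pairs: the same change on two cores in this assay, a 1.3-fold lower number (0.10 log units; within the scatter) from compound 2 to compound 3 and a 1.2-fold higher number (0.07 log units; within the scatter) from compound 4 to compound 1, 1.5-fold (0.17 log units) apart, within the scatter of two such steps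

From the compounds shown here alone, whether an amine, a carboxylic acid or a longer chain at this position would shift the half-life beyond the scatter remains open.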